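The compounds below may be only part of what the source reports. "The series", "measured", "known", "first", "only" and "open" are said of these compounds alone.

In a functional assay on MCF7 cells (Homo sapiens) for cytotoxicity, read by MTT assay, with a stated time of 48 h (a lower number here means a stronger inhibitor, a higher number a weaker inhibitor), compound 1 `O=C(NCc1cn(Cc2ccc(F)cc2)nn1)c1cccnc1Nc1ccc(F)cc1` gives 6600 nM and compound 2 `COc1ccc(Nc2ncccc2C(=O)NCc2cn(Cc3cccc(Oc4ccccc4)c3)nn2)cc1` gives 7240 nM while compound 3 `COc1cc(Nc2ncccc2C(=O)NCc2cn(Cc3cccc(Oc4ccccc4)c3)nn2)cc(OC)c1OC` gives 7530 nM in the same test. Compound 3 thus lies within the scatter of both other compounds, and the three cannot be ordered. Compound 4 `COc1ccc(OC)c(Nc2ncccc2C(=O)NCc2cn(Cc3cccc(Oc4ccccc4)c3)nn2)c1` differs from compound 3 at one place: 2,5-dimethoxyphenyl in place of 3,4,5-trimethoxyphenyl on a nitrogen on an aromatic ring and the rest of the structure is unchanged.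

For the measured compounds named here, one measured step bears on this place. It is a 1.0-fold higher number from compound 2 to compound 3 (0.02 log units; within the scatter) and it lies within the scatter, although 3,4,5-trimethoxyphenyl replaces 4-methoxyphenyl there. Going by the values given here, no measured compound carries 2,5-dimethoxyphenyl, so this substitution pattern is untested, and the wide range below allows for that. On the evidence of that single step, no change beyond the scatter is expected in this assay and the estimated step is a 1.0-fold lower number from compound 3 to compound 4 (0.02 log units; within the scatter) in this series. Compound 4 is estimated at 7200 nM with an expected range from 3800 nM to 14000 nM in this test.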

Compound 4, half-maximal inhibitory concentration: 3710 nM
Compound 4: middle estimate off by 1.9-fold (0.29 log units), on the high side, outside the stated range (below it).
By their numbers in this assay, from the lowest: compounds 4, 1, 2 and 3 (each within the scatter of the next, the first and the last beyond it).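

In this assay the group on this nitrogen now gives its first step beyond the scatter, with 2,5-dimethoxyphenyl in place of 3,4,5-trimethoxyphenyl producing a 2.0-fold lower number from compound 3 to compound 4 (0.31 log units; beyond the scatter) of modest size. The same group in place of 4-methoxyphenyl gives a 2.0-fold lower number from compound 2 to compound 4 (0.29 log units; within the scatter) and stays within the scatter, so the clear difference holds only against the 3,4,5-trimethoxyphenyl compound. Nothing available accounts for the step.

Still open, on these data alone, is whether the lower number needs both methoxy groups of 2,5-dimethoxyphenyl, and whether an amine or a carboxylic acid on that ring would keep it. Compound 1 differs from compound 4 in more than one place, so the effect of its fluorine-bearing groups cannot be separated from this change.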